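The source may report more compounds than this note shows. Statements on the series, on what has been measured and on what is new or still open speak of the compounds shown alone.

Of the compounds shown here, two from this set have been tested, and one more awaits its turn. Compound 1 `COc1ccc(-n2cc(-c3ccc(OC)c(OC)c3)nn2)cc1` and compound 2 `COc1ccc(-c2cn(-c3ccc(OC(F)(F)F)cc3)nn2)cc1` share a core built around a triazole ring carrying two substituted benzene rings. In a functional assay on MDA-MB-231 cells (Homo sapiens) for cytotoxicity, read by MTT assay (on this read-out higher numbers stand for weaker inhibition and lower numbers for stronger inhibition), compound 2 gives 1000 nM, and this is the only numerical result in the set. For compound 1 the result in this assay is only a limit of the measurement, reported as > 100 nM; the corresponding description is the limit of > 100 nM in this assay, at which 1 of the 2 values shown sits. So compound 2 stands alone as the single compound with a number, with nothing to compare it against.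

Compound 3 `COc1ccc(-c2cn(-c3ccc(OC)cc3)nn2)cc1` is the next step, and it differs from compound 2 in one place: methyl in place of trifluoromethyl on an oxygen on an aromatic ring. Going by the values given here, since no measured pair in this set shows such a change, its size is not known from the data. The expectation for compound 3 is a step of a 1.5-fold higher number from compound 2 to compound 3 (0.18 log units; within the scatter), small enough to stay within the usual scatter, so compound 3 is estimated at 1500 nM in this assay, in a range from 500 nM to 5000 nM.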

Compound 3, half-maximal inhibitory concentration: > 100 nM
Compound 3 gave a limit, no number; the forecaster's own chance of this, stated with the estimate: 15%; the middle value does not contradict the limit.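

No step to compound 3 can be read from compound 1 or compound 2, because compound 3, like compound 1, gives a limit and not a number: the limit of > 100 nM in this assay, at which 2 of the 3 values shown sit.

The compounds shown leave open whether going from trifluoromethoxy to methoxy changes the result in this assay at all.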